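The source may report more compounds than this note shows. Statements on the series, on what has been measured and on what is new or still open speak of the compounds shown alone.

Working notes on the series.

Compound 1 `Nc1scc(CN2CCN(c3cccnc3)CC2)c1C(=O)c1ccc(Cl)cc1` stands highest of the three numbers in a functional assay on CHO cells with adenosine receptor A1 (Homo sapiens) as the target, read by cAMP accumulation and immunoassay, with a stated time of 6 min, tested at 0.1 uM (on this read-out higher numbers stand for a weaker effect at the one concentration tested and lower numbers for a stronger effect), where compound 1 gives 3.4%. Compound 2 `Nc1scc(CN2CCN(c3ccc(C(F)(F)F)cc3)CC2)c1C(=O)c1cccc(C(F)(F)F)c1` gives in this assay -11%, and compound 3 `Nc1scc(CN2CCN(c3cccc(F)c3)CC2)c1C(=O)c1cccc(C(F)(F)F)c1` gives in this assay -12%; both of these lie beyond the scatter from compound 1, and compound 2 and compound 3 lie within the scatter of each other. Within the data shown here, the one step measured in one place, a number 1 percentage points lower from compound 2 to compound 3 (within the scatter), exchanges the aryl on an amine nitrogen in a ring and leaves the read-out essentially unchanged. Compound 2 differs from compound 1 in two places at once, so its gap to compound 1 cannot be laid to either place.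

Compound 4 `Nc1scc(CN2CCN(c3cccc(F)c3F)CC2)c1C(=O)c1ccc(Cl)cc1` is not yet measured. It differs from compound 1 by 2,3-difluorophenyl in place of pyridin-3-yl on an amine nitrogen in a ring. Among the measured compounds shown here, the only step that bears on it is the aryl exchange on the same ring nitrogen, which was within the scatter, so no step beyond the scatter is expected in this assay. The estimate for compound 4 in this assay is 0%, within -14% to 12%, meaning an expected step of a number 3.4 percentage points lower from compound 1 to compound 4 (within the scatter).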

Compound 4, a percentage reported as activity, at one concentration (the size of the read-out at that concentration, not a potency): -5.2%
The estimate for compound 4 lay 5.2 percentage points above the measured number; the range from low to high includes it.
By their numbers in this assay, from the lowest: compounds 3, 2, 4 and 1 (each within the scatter of the next, the first and the last beyond it).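

A second aryl exchange on the amine nitrogen in a ring, 2,3-difluorophenyl in place of pyridin-3-yl, is now read in this assay as a number 8.6 percentage points lower from compound 1 to compound 4 (within the scatter) and sets a pair at this position on a different ketone aryl from the earlier step. Where the earlier exchange had a carbon-only aryl on both sides, this one takes out the aromatic ring nitrogen and the hydrogen-bond acceptor counted with it, and the read-out stays within the scatter. No measurement at hand gives a reason for this result.

The compounds shown leave open whether a piperazine nitrogen carrying a methyl group or a cyclohexyl ring instead of an aryl would stay in this range. They also leave open whether 2,3-difluorophenyl reads the same with the trifluoromethyl-bearing phenyl on the carbonyl.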